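Series notes: methyl on the ring nitrogen

The source may hold more compounds than are shown below. What is called first, only, known or untested is meant among the compounds shown, and "the series" means these compounds.

Among the compounds with values here, compound 1 `Cc1ccc(S(=O)(=O)Nc2cc[nH]c(=O)n2)cc1` is the only member with a numerical result so far. In a functional assay on MCF7 cells (Homo sapiens) for inhibition, read by MTT assay, with a stated time of 72 h (on this read-out higher numbers stand for weaker inhibition and lower numbers for stronger inhibition), compound 1 gives 27000 nM. Compound 2 `CSc1cc[nH]c(=O)n1` returns only a limit of the assay: in this assay compound 2 reads > 100000 nM, which is a limit and not a number. Within the data shown here, the evidence the limit of > 100000 nM in this assay, at which 1 of the 2 values shown sits, shows that one of the two values sits at that limit, so compound 1 stands as the single measured point, and no step between two measured compounds exists in this set.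

Compound 3 `Cc1ccc(S(=O)(=O)Nc2ccn(C)c(=O)n2)cc1` has not yet been measured. Relative to compound 1 the change is methyl in place of hydrogen on an aromatic nitrogen. Among the measured compounds shown here, no measured step of this kind is available, so the direction is open; a small loss, at or somewhat beyond the scatter, is expected, though a result within the scatter of compound 1 cannot be excluded. For compound 3 the expected step is a 1.9-fold higher number from compound 1 to compound 3 (0.27 log units; within the scatter). Compound 3 is estimated at 50000 nM, with a range from 15000 nM to 150000 nM.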

Compound 3, half-maximal inhibitory concentration: > 100000 nM
Compound 3 was reported as a limit; the forecaster's own chance of this, stated with the estimate: 35%; at least 2.0-fold (0.30 log units) between middle value and limit.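

In this assay compound 3 reads > 100000 nM, which is a limit of the assay and not a number. On these data alone, this gives the series its first step at this position: methyl in place of hydrogen on an aromatic nitrogen produces an at least 3.7-fold higher number from compound 1 to compound 3 (0.56 log units; beyond the scatter), so in this set the change costs activity beyond the scatter, while the full size of the loss remains unknown. Compound 1 is now the only compound with a numerical result, and the other two readings sit at the same limit: the limit of > 100000 nM in this assay, at which 2 of the 3 values shown sit.

As far as these compounds go, it remains open whether the loss is specific to methyl or extends to other groups on this nitrogen, such as ethyl or 2-hydroxyethyl. Within the data shown here, how an amine or a carboxylic acid elsewhere on the core of compound 1 would read is also open, as the single measured step speaks only for this ring nitrogen and gives no guide to any other place.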